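Hydroxy on compound 2: an untested change

The compounds below may be only part of what the source reports. "The series", "measured", "known", "first", "only" and "open" are said of these compounds alone.

In a functional assay (a lower number here means a stronger inhibitor, a higher number a weaker inhibitor), compound 1 `CC(C)=CCOc1ccc2c(c1)OC(c1cccc(Cl)c1)CC2=O` gives 6300 nM while compound 2 `CC(C)=CCOc1ccc2c(c1)OC(c1ccc(Cl)cc1Cl)CC2=O` gives 5260 nM and compound 3 `CC(C)=CCOc1ccc2c(c1)OC(c1ccccc1Br)CC2=O` gives 3180 nM on the shared core. Compound 2 does not stand apart from the other two. The steps are a 1.2-fold lower number from compound 1 to compound 2 (0.08 log units; within the scatter) and a 1.7-fold lower number from compound 2 to compound 3 (0.22 log units; within the scatter) and a 2.0-fold lower number from compound 1 to compound 3 (0.30 log units; within the scatter) with none of them separating the three.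

Compound 4 `CC(C)=CCOc1cc(O)c2c(c1)OC(c1ccc(Cl)cc1Cl)CC2=O` differs from compound 2 by one change, hydroxy in place of hydrogen on an aromatic carbon which is hydroxy in place of hydrogen on an aromatic carbon. All three measured steps exchange the phenyl group on a saturated ring carbon, and none touches this aromatic carbon. They therefore bear on it only weakly, and the data hold no measured hydroxy effect. From the compounds shown here alone, no step beyond the scatter is expected in this assay and the direction remains open. The expectation stays anchored on compound 2 at 5260 nM as its starting point. The estimate amounts to a 1.3-fold lower number from compound 2 to compound 4 (0.12 log units; within the scatter) as the expected step. Compound 4 is estimated at 4000 nM with an expected range of 1200 nM to 13000 nM for this measurement.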

Compound 4, half-maximal inhibitory concentration: 3340 nM
Estimate against measurement, compound 4: 1.2-fold (0.08 log units) above, within the range that was stated.
By their numbers in this assay, from the lowest: compounds 3, 4, 2 and 1 (each within the scatter of the next).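

Notes on the aromatic carbon ortho to a fused ring: in this assay, hydroxy in place of hydrogen gives a 1.6-fold lower number from compound 2 to compound 4 (0.20 log units; within the scatter), the first reading of a change at this carbon, since the earlier steps all exchanged the phenyl group on a saturated ring carbon. The step does not separate compound 4 from compound 2, so on the 2,4-dichlorophenyl compound this position carries hydroxy without a step beyond the scatter, and no direction can be assigned to the change. Nothing available accounts for the result, or gives any property of the hydroxy group here.

Still open, from the compounds shown here alone, is what methoxy or an amine on this aromatic carbon would give. Also open, going by these compounds, is whether hydroxy gives a step of like size with 2-bromophenyl or 3-chlorophenyl on the saturated ring carbon.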